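Chain homologue of a hydroxylated butenolide antiproliferative

The source may hold more compounds than are shown below. What is called first, only, known or untested is meant among the compounds shown, and "the series" means these compounds.

Measured compounds:
- compound 1, `C=C(C)CCC[C@]1(C)C2=CCC[C@](C)(C[C@H](O)c3ccoc3)[C@H]2CC[C@H]1C`: 66000 nM
- compound 2, `C=C(C)CC[C@]1(C)C2=CCC[C@](C)(C[C@H](O)C3=CC(=O)OC3O)[C@H]2CC[C@H]1C`: 4500 nM

In a functional assay on A549 cells (Homo sapiens) for antiproliferative activity, read by XTT assay, with a stated time of 72 h (on this read-out higher numbers stand for weaker inhibition and lower numbers for stronger inhibition), compound 2 gives the lowest of the two numbers, and compound 1 gives a number that stands well beyond the scatter above it. Compound 3, `C=C(C)CCC[C@]1(C)C2=CCC[C@](C)(C[C@H](O)C3=CC(=O)OC3O)[C@H]2CC[C@H]1C`, is not yet measured. It differs from compound 2 at the saturated chain carbon two bonds along the chain from a saturated ring carbon: 2-methylprop-2-en-1-yl in place of 1-methylethenyl on a saturated chain carbon, two bonds along the chain from a saturated ring carbon. Within the data shown here, no measured pair isolates this change, so the account expects a step from compound 2 to compound 3 of a 1.1-fold higher number from compound 2 to compound 3 (0.05 log units; within the scatter), none beyond the scatter. Compound 3 is estimated at 5000 nM, within 2000 nM to 12000 nM.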

Compound 3, half-maximal inhibitory concentration: 3200 nM
Estimate against measurement, compound 3: 1.6-fold (0.19 log units) above, within the range that was stated.
By their numbers in this assay, from the lowest: compounds 3 and 2 (each within the scatter of the next); then compound 1.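

In this assay the change to 2-methylprop-2-en-1-yl from 1-methylethenyl, on a saturated chain carbon, two bonds along the chain from a saturated ring carbon, gives a 1.4-fold lower number from compound 2 to compound 3 (0.15 log units; within the scatter) and so leaves the activity unchanged within the scatter. With the chain now matched to that of compound 1, the ring exchange alone gives a 21-fold lower number from compound 1 to compound 3 (1.31 log units; beyond the scatter) as the five-membered aromatic ring gives way to the five-membered non-aromatic ring. No measurement given here accounts for either step. Still open, as far as these compounds go, is whether the longer 3-methylbut-3-en-1-yl chain would hold this activity. From the compounds shown here alone, a carboxylic acid at the chain end also remains untested here.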